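The source may hold more compounds than are shown below. What is called first, only, known or untested is meant among the compounds shown, and "the series" means these compounds.

Compound 1 `COc1ccccc1OCC1SCCN1C(=O)C[S+](C)[O-]`: 10 mg/kg
Compound 2 `COc1ccccc1OCC1SCCN1C(=O)C(C)(C)C(=O)O`: 21 mg/kg

In a functional assay on the whole organism (trachea) for inhibition, with Cavia porcellus as the target (on this read-out higher numbers stand for an effect only at larger amounts of compound and lower numbers for an effect already at smaller amounts), compound 2 holds the higher of the two numbers. Compound 3 `CNC(=O)CC(=O)N1CCSC1COc1ccccc1OC` differs from it by (methylcarbamoyl)methyl in place of 1-carboxy-1-methylethyl on a carbonyl carbon. For the measured compounds named here, only one measured step bears on this place, the modest 2.1-fold higher number from compound 1 to compound 2 (0.32 log units; beyond the scatter), which lies beyond the scatter. With so little evidence, a similarly modest move back towards the lower number is expected, and the estimated step is a 1.5-fold lower number from compound 2 to compound 3 (0.18 log units; within the scatter). Compound 3 is estimated at 14 mg/kg, with an expected range from 5 mg/kg to 40 mg/kg.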

Compound 3, dose for half-maximal effect: 22 mg/kg
Beside the measured number, compound 3's estimate is 1.6-fold (0.20 log units) below it; measured number inside the range.
By their numbers in this assay, from the lowest: compound 1; then compounds 2 and 3 (each within the scatter of the next).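

In this assay, putting (methylcarbamoyl)methyl in place of 1-carboxy-1-methylethyl on the carbonyl carbon gives a 1.0-fold higher number from compound 2 to compound 3 (0.02 log units; within the scatter) and leaves the two compounds level, so this position tolerates that exchange of groups with no visible shift. Compound 1 stays apart from the new compound, with a 2.2-fold higher number from compound 1 to compound 3 (0.34 log units; beyond the scatter) as the printed gap, which matches the gap already seen for compound 2. Nothing available here accounts for these numbers. As far as these compounds go, whether a simple amine or a longer chain on this carbonyl carbon would come closer to compound 1 remains open.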